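Removing the Prenyl Ether from a Cinnamyl Alcohol

The compounds below may be only part of what the source reports. "The series", "measured", "known", "first", "only" and "open" are said of these compounds alone.

Of the compounds shown here, three have been tested in a functional assay on U-373MG ATCC cells (Homo sapiens) for cytotoxicity, read by MTT assay, with a stated time of 72 h; a lower number here means a stronger inhibitor, a higher number a weaker inhibitor. Compound 1 `C=C(C)CCOc1ccc(C(C)=O)c(O)c1` is a small acetophenone carrying a 3-methylbut-3-en-1-yl ether. For compound 1 the assay reports only a limit, > 100000 nM, rather than a number. Compound 2 `C=C(C)CCOc1c(OC)cc(/C=C/CO)cc1OC` places the same ether on a dimethoxy-substituted cinnamyl alcohol. For compound 2 the result is again a limit, > 100000 nM, not a measured number. Compound 3 `COc1cc(/C=C/CO)ccc1OC/C=C(\C)CCC=C(C)C` carries a longer, branched chain on the ether oxygen, and in this assay compound 3 gives 25000 nM. Compound 2 thus stands at the limit of > 100000 nM in this assay, at which 2 of the 3 values shown sit, with no number of its own to compare.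

Compound 4 `COc1cc(/C=C/CO)cc(OC)c1O` is the next candidate. It differs from compound 2 in one place: hydrogen in place of 3-methylbut-3-en-1-yl on an oxygen on an aromatic ring. The change strips the only chain away from the oxygen, leaving a bare hydroxy on the shared core. For the measured compounds named here, with both chain-bearing ethers at the limit, no measured step gives a direction, and the expected step that the limit leaves unreadable from compound 2 to compound 4 is none beyond the scatter. Compound 4 is therefore estimated at 150000 nM, within 40000 nM to 600000 nM.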

Compound 4, half-maximal inhibitory concentration: > 100000 nM
Compound 4 gave a limit, no number (the forecaster's own chance of this, stated with the estimate: 70%); the middle value does not contradict the limit.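

For the compounds shown here, compound 2 and compound 4 both stand at a limit of the assay rather than at a number, so no step between them can be read: the limit of > 100000 nM in this assay, at which 3 of the 4 values shown sit.

In this assay the compounds shown leave open whether hydrogen in place of 3-methylbut-3-en-1-yl on this oxygen changes the cytotoxicity at all.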